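Exchanging one aromatic group on compound 2

This account rests on a few compounds, and the source may have more. Where it says the series, first, only, none or still open, it means among the compounds named here.

For the measured compounds named here, in a physicochemical assay for solubility, read by LC-MS, in phosphate buffer, with a stated time of 24 h, at pH 7.4 (on this read-out higher numbers stand for higher solubility and lower numbers for lower solubility), compound 2 (`Cc1cc(-c2cnc(NCc3c(F)ccc4c3CCO4)c3cn[nH]c(=O)c23)n(C)n1`) gives 1000 nM, the lower of two numbers so far, while compound 1 (`Cc1nc(CO)ccc1-c1cnc(NCc2c(F)ccc3c2CCO3)c2cn[nH]c(=O)c12`) gives 3000 nM. Compound 3 (`Cc1ncccc1-c1cnc(NCc2c(F)ccc3c2CCO3)c2cn[nH]c(=O)c12`) carries 2-methylpyridin-3-yl in place of 1,3-dimethyl-1H-pyrazol-5-yl on an aromatic carbon. Going by the values given here, the one measured step bearing on this is modest: a 3.0-fold lower number from compound 1 to compound 2 (0.48 log units; beyond the scatter), where 1,3-dimethyl-1H-pyrazol-5-yl replaced 6-(hydroxymethyl)-2-methylpyridin-3-yl. The entering group lacks that hydroxymethyl, so a smaller, upward step is expected in this assay: a 1.4-fold higher number from compound 2 to compound 3 (0.15 log units; within the scatter). For compound 3 the estimated value is 1400 nM, with an expected range from 500 nM to 3500 nM.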

Compound 3, solubility: < 2000 nM
Compound 3: a limit, no number (the forecaster's own chance of this, stated with the estimate: 10%); the middle value is on the limit's open side.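

For compound 3, the result in this assay is a limit and not a number: the limit of < 2000 nM in this assay, at which 1 of the 3 values shown sits. For the compounds shown here, with hydrogen in place of hydroxymethyl, the only change in this pair, the data give an at least 1.5-fold lower number from compound 1 to compound 3 (0.17 log units; that floor lies within the scatter). The step from pyrazolyl compound 2 to this pyridinyl compound cannot be read, so the exchange of the two aromatic groups remains unsized.

As far as these compounds go, the real size of the hydroxymethyl effect remains open, since only a floor is available. Also open, from the compounds shown here alone, is how an amine or a carboxylic acid would read on the 2-methylpyridin-3-yl ring in place of hydroxymethyl.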